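A second nitrile arm on the amide of compound 3

A few compounds are considered here, and "the series" means these few. Any claim that something is new, unique, unknown or untested is made for them only; others in the source may bear on it.

Compound 3 `CCn1c(C(=O)NCC#N)ccc1C(CC)(CC)c1ccc(OCCC(O)(CC)CC)c(C)c1` is the weakest of the three measured compounds in an assay on cells for agonist activity at vitamin D3 receptor (Homo sapiens), with a stated time of 96 h; on this read-out lower numbers stand for an effect already at smaller amounts and higher numbers for an effect only at larger amounts of compound: compound 3 gives 1080 nM, whereas compound 1 `CCn1c(C(=O)NCCCN(C)C)ccc1C(CC)(CC)c1ccc(OCCC(O)(CC)CC)c(C)c1` gives 5 nM and compound 2 `CCn1c(C(=O)NCCN(C)C)ccc1C(CC)(CC)c1ccc(OCCC(O)(CC)CC)c(C)c1` gives 82 nM. Both steps towards it raised the number clearly: a 16-fold higher number from compound 1 to compound 2 (1.21 log units; beyond the scatter), and a 13-fold higher number from compound 2 to compound 3 (1.12 log units; beyond the scatter).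

Compound 4 `CCn1c(C(=O)N(CCC#N)CCC#N)ccc1C(CC)(CC)c1ccc(OCCC(O)(CC)CC)c(C)c1` differs from compound 3 by a group of 9 heavy atoms (6 carbon, 3 nitrogen; no ring) in place of a group of 4 heavy atoms (2 carbon, 2 nitrogen; no ring), on a carbonyl carbon: the amide hydrogen is gone and a second nitrile-bearing chain enters. For the measured compounds named here, no measured step removes an amide hydrogen or adds a second nitrile, so the closest guide is the step from compound 2 to compound 3, in which a nitrile arm replaced a dimethylamino-bearing one and the number rose sharply. Compound 4 keeps nitriles and has no dimethylamino group, so it is expected to stay in the weak range, with a small rise estimated as a 1.9-fold higher number from compound 3 to compound 4 (0.27 log units; within the scatter). The expected value for compound 4 is 2000 nM, within 500 nM to 8000 nM.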

Compound 4, half-maximal effective concentration: > 10000 nM
Compound 4: a limit, no number (the forecaster's own chance of this, stated with the estimate: 15%); at least 5.0-fold (0.69 log units) between middle value and limit.
By their numbers in this assay, from the lowest: compound 1; then compound 2; then compound 3. At a limit, above all of these: compound 4.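

Compound 4 has no number in this assay, only a limit: the limit of > 10000 nM in this assay, at which 1 of the 4 values shown sits. This is the first change shown that removes the amide hydrogen, and with an at least 9.2-fold higher number from compound 3 to compound 4 (0.96 log units; beyond the scatter), it shows that this place on the carbonyl carbon still had room to lose activity even after the nitrile arm of compound 3. Set against the dimethylamino compounds, the change gives an at least 120-fold higher number from compound 2 to compound 4 (2.08 log units; beyond the scatter) and an at least 2000-fold higher number from compound 1 to compound 4 (3.30 log units; beyond the scatter), so the amide substituent alone spans a very wide range in this series.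

Compound 4 loses the amide hydrogen and gains a second nitrile-bearing chain in a single change, and the compounds shown cannot separate the two. A single 2-cyanoethyl chain with the amide hydrogen kept, or a methyl group on the amide nitrogen of compound 1, would pull them apart.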